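Replacing the propargyl ester of compound 3 with an amino acid amide

The source may hold more compounds than are shown below. What is called first, only, known or untested is meant among the compounds shown, and "the series" means these compounds.

Compound 3 `C#CC(C)OC(=O)c1ccc(C(CC)(CC)c2ccc(OCCC(O)(CC)CC)c(C)c2)n1CC` gives 2650 nM in an assay on cells for agonist activity at vitamin D3 receptor (Homo sapiens), with a stated time of 96 h (a lower number here means that less compound is needed, a higher number that more compound is needed for the effect), the highest of the two numbers shown. Its nearest neighbour is compound 1 `CCN(CC)CCNC(=O)c1ccc(C(CC)(CC)c2ccc(OCCC(O)(CC)CC)c(C)c2)n1CC`, which gives 2.3 nM in this assay. Compound 2 `CCn1c(C(=O)N(CCC#N)CCC#N)ccc1C(CC)(CC)c1ccc(OCCC(O)(CC)CC)c(C)c1` reaches only a limit in this assay, > 10000 nM (the limit of > 10000 nM in this assay, at which 1 of the 3 values shown sits). Among the measured steps, a 1200-fold higher number from compound 1 to compound 3 (3.06 log units; beyond the scatter) and an at least 4300-fold higher number from compound 1 to compound 2 (3.63 log units; beyond the scatter), while an at least 3.7-fold lower number from compound 2 to compound 3 (0.57 log units; beyond the scatter).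

Compound 4 `CCC(C)C(NC(=O)c1ccc(C(CC)(CC)c2ccc(OCCC(O)(CC)CC)c(C)c2)n1CC)C(=O)O` differs from compound 3 by (1-carboxy-2-methylbutyl)amino in place of (1-methylprop-2-yn-1-yl)oxy on a carbonyl carbon. The step that bears most directly on this change is a 1200-fold higher number from compound 1 to compound 3 (3.06 log units; beyond the scatter), which shows that a secondary amide on this carbonyl carbon, as in compound 1, sits far below the ester of compound 3. Compound 4 restores a secondary amide, but its entering group carries a carboxylic acid that neither compound 1 nor compound 2 has, and compound 2 shows that not every amide retains the number of compound 1. Compound 4 is therefore expected to give a lower number than compound 3, a step of an 8.8-fold lower number from compound 3 to compound 4 (0.95 log units; beyond the scatter), though probably not all the way to compound 1. The estimate for compound 4 in this assay is 300 nM, with a range from 30 nM to 3000 nM.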

Compound 4, half-maximal effective concentration: 860 nM
The estimate for compound 4 lay 2.9-fold (0.46 log units) below the measured number; the measured number falls inside the stated range.
By their numbers in this assay, from the lowest: compound 1; then compound 4; then compound 3. At a limit, above all of these: compound 2.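

In this assay, exchanging the ester for a secondary amide bearing (1-carboxy-2-methylbutyl)amino gives a 3.1-fold lower number from compound 3 to compound 4 (0.49 log units; beyond the scatter), so an amide on this carbonyl carbon is not enough by itself to reach the number of compound 1. The two secondary amides still lie far apart, with a 370-fold higher number from compound 1 to compound 4 (2.57 log units; beyond the scatter), which puts much of the weight at this position on the group carried by the amide nitrogen, here 1-carboxy-2-methylbutyl against 2-(diethylamino)ethyl, and not on the amide link alone. The remaining step, an at least 11-fold lower number from compound 2 to compound 4 (1.06 log units; beyond the scatter), is read against a limit and gives only a bound: the limit of > 10000 nM in this assay, at which 1 of the 4 values shown sits.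

The compounds shown do not separate the carboxylic acid of the entering group from the rest of that group, so it remains open which part holds the number above that of compound 1. As far as these compounds go, it also stays open how a methyl ester in place of that carboxylic acid, or a primary amine in place of the diethylamino end of compound 1, would read in this assay.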